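A few compounds are considered here, and "the series" means these few. Any claim that something is new, unique, unknown or untested is made for them only; others in the source may bear on it.

Measured: compound 1 `C#Cc1ccc2ncn(-c3ccnc(N)n3)c2c1` with 251 nM; compound 2 `C=Cc1ccnc(C#Cc2ccc3ncn(-c4ccnc(N)n4)c3c2)c1` with 1580 nM.

In an assay on Sf9 cells for inhibition of mitogen-activated protein kinase kinase kinase 14 variant S549D (Homo sapiens), with a stated time of 30 min, in the presence of a further agent that is not named here (on this read-out lower numbers stand for stronger inhibition and higher numbers for weaker inhibition), compound 1 gives 251 nM and compound 2 gives 1580 nM. For the measured compounds named here, compound 2 holds the highest of the two numbers; the only measured step, a 6.3-fold higher number from compound 1 to compound 2 (0.80 log units; beyond the scatter), attaches the ring-bearing group at the triple-bonded carbon. Compound 3 `C#Cc1cc(C#Cc2ccc3ncn(-c4ccnc(N)n4)c3c2)ccn1` is not yet measured; it differs from compound 2 by a group of 8 heavy atoms (7 carbon, 1 nitrogen; one six-membered aromatic ring with 1 hetero atom) in place of a group of 8 heavy atoms (7 carbon, 1 nitrogen; one six-membered aromatic ring with 1 hetero atom), on a triple-bonded carbon. Going by the values given here, no measured step exchanges one such group for another, so that step bears on this change only loosely and fixes no direction. A step within the scatter is expected for compound 3, a 1.1-fold lower number from compound 2 to compound 3 (0.05 log units; within the scatter). Compound 3 is estimated at 1400 nM, range 500 nM to 4000 nM.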

Compound 3, half-maximal inhibitory concentration: 31600 nM
Beside the measured number, compound 3's estimate is 23-fold (1.35 log units) below it; measured number outside the range, above it.
By their numbers in this assay, from the lowest: compound 1; then compound 2; then compound 3.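

In this assay, the exchange on the triple-bonded carbon gives a 20-fold higher number from compound 2 to compound 3 (1.30 log units; beyond the scatter), although the leaving and entering groups match in every count under comparison except that a double bond outside the aromatic ring gives way to a triple bond. This position therefore distinguishes between two closely matched ring-bearing groups, and with a hydrogen atom as the reference the entering group gives a 130-fold higher number from compound 1 to compound 3 (2.10 log units; beyond the scatter). No measurement shown here accounts for this difference. Still open, on these data alone, is how an amine or a longer alkyl chain in place of the entering group would read at this carbon. Also open, as far as these compounds go, is whether any ring-bearing group here can match compound 1.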